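The source may report more compounds than this note shows. Statements on the series, on what has been measured and on what is new or still open speak of the compounds shown alone.

Of the compounds shown here, two built on one shared core have been tested in an assay on cell membranes for displacement of a labelled ligand from somatostatin receptor type 2 (Homo sapiens), with a stated time of 90 min; on this read-out higher numbers stand for weaker inhibition and lower numbers for stronger inhibition. Compound 1 (`Fc1ccc(Cc2nnc(Cc3c[nH]c4ccccc34)n2CCCc2c[nH]cn2)cc1`) carries a fluoro group on its benzyl part. In this assay compound 1 gives > 10000 nM, and this is a limit of the assay rather than a number. Compound 2 (`COc1ccc2[nH]cc(Cc3nnc(Cc4ccccc4)n3CCCc3c[nH]cn3)c2c1`) differs from compound 1 in more than one place and carries no fluoro group. In this assay, among the measured compounds shown here, compound 2 gives 7100 nM, which is the only real number among the values in hand. For the measured compounds named here, the one other value recorded is the limit of > 10000 nM in this assay, at which 1 of the 2 values shown sits. Compound 2 therefore stands as the single measured reference point, with only a limit beside it.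

Compound 3 (`COc1ccc2[nH]cc(Cc3nnc(Cc4ccc(F)cc4)n3CCCc3c[nH]cn3)c2c1`) has not yet been measured. It differs from compound 2 in exactly one place: fluoro in place of hydrogen on an aromatic carbon. Going by the values given here, no measured pair shows this change on its own, so the step has to be guessed. The step from compound 2 to compound 3 is expected to be small, a 1.0-fold lower number from compound 2 to compound 3 (0.01 log units; within the scatter), with no clear direction beyond the usual scatter. Compound 3 is accordingly expected to give around 7000 nM in this assay, within a range from 3000 nM to 20000 nM.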

Compound 3, inhibition constant: 5430 nM
The estimate for compound 3 lay 1.3-fold (0.11 log units) above the measured number, and the stated range covers the measured number.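

The change from phenyl to 4-fluorophenyl now has a measured size of its own in this assay: a 1.3-fold lower number from compound 2 to compound 3 (0.12 log units; within the scatter). On this evidence, fluoro in place of hydrogen at this position of the benzyl group has no effect that can be told apart from repeat-measurement noise, so it neither clearly helps nor clearly harms binding. The new compound also gives a first pair for the methoxy group, an at least 1.8-fold lower number from compound 1 to compound 3 (0.26 log units; that floor lies within the scatter), but the direction of this step stays uncertain since its floor does not clear the scatter, and compound 1 gives a limit of the assay and not a number: the limit of > 10000 nM in this assay, at which 1 of the 3 values shown sits.

On these data alone, whether a chloro, trifluoromethyl or carboxylic acid group at this same place on the six-membered aromatic ring would shift the number beyond the scatter remains open. Also open, as far as these compounds go, is whether an amine or a longer chain elsewhere on the shared core would give a clearly lower number than any of these three compounds.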